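Moving the Thiophene Attachment Point in a Urea Series

The source may report more compounds than this note shows. Statements on the series, on what has been measured and on what is new or still open speak of the compounds shown alone.

Compound 3 `Cc1cc(C)c(NC(=O)N(Cc2ccc(-c3cccs3)cc2)C2CCCCCC2)c(C)c1` carries a thiophen-2-yl group on the benzyl ring of its urea; in an assay on microsomes from intestine for inhibition of acyl-CoA:cholesterol acyltransferase (Oryctolagus cuniculus) (on this read-out higher numbers stand for weaker inhibition and lower numbers for stronger inhibition), compound 3 gives 22 nM. Among the three measured compounds it holds the second highest number. Compound 1 `O=C(Nc1c(F)cc(F)cc1F)N(Cc1ccc(-c2cccs2)cc1)C1CCCCCC1` gives 18 nM in this assay, and a 1.2-fold higher number from compound 1 to compound 3 (0.09 log units; within the scatter). Compound 2 `Cc1cc(C)c(NC(=O)N(Cc2ccc(-c3n[nH]c(C)n3)cc2)C2CCCCCC2)c(C)c1` gives 120 nM in this assay, and a 5.5-fold lower number from compound 2 to compound 3 (0.74 log units; beyond the scatter).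

Compound 4 `Cc1cc(C)c(NC(=O)N(Cc2ccc(-c3ccsc3)cc2)C2CCCCCC2)c(C)c1` is next in line; its difference from compound 3 is thiophen-3-yl in place of thiophen-2-yl on an aromatic carbon. For the measured compounds named here, no measured step shifts the attachment point of the thiophene. The step of a 5.5-fold lower number from compound 2 to compound 3 (0.74 log units; beyond the scatter) concerns the same position but exchanges one heterocycle for a different one, and the step of a 1.2-fold higher number from compound 1 to compound 3 (0.09 log units; within the scatter) touches another part of the molecule. With the ring kept and only its attachment changed, compound 4 is expected to show a 1.4-fold higher number from compound 3 to compound 4 (0.13 log units; within the scatter), a step of no clear direction and probably within the scatter. The estimate for compound 4 in this assay is 30 nM, with a range from 10 nM to 90 nM.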

Compound 4, half-maximal inhibitory concentration: 19 nM
Compound 4: middle estimate off by 1.6-fold (0.20 log units), on the high side, and the stated range covers the measured number.
By their numbers in this assay, from the lowest: compounds 1, 4 and 3 (each within the scatter of the next); then compound 2.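

In this assay, shifting the thiophene attachment gives a 1.2-fold lower number from compound 3 to compound 4 (0.06 log units; within the scatter), so at this position, para to a large group, the assay does not separate thiophen-3-yl from thiophen-2-yl. The gap to the triazole also holds for both attachments, at a 5.5-fold lower number from compound 2 to compound 3 (0.74 log units; beyond the scatter) and a 6.3-fold lower number from compound 2 to compound 4 (0.80 log units; beyond the scatter), so the higher number of compound 2 does not depend on which thiophene attachment it is set against. No measurement at hand explains why the two thiophenes match or why the triazole differs from them.

The compounds shown leave open whether thiophen-3-yl would match thiophen-2-yl with 2,4,6-trifluorophenyl in place of 2,4,6-trimethylphenyl on the amide-type nitrogen. They also leave open whether a furan-2-yl, a pyridin-3-yl or a plain phenyl ring at this position would stay with the thiophenes or move towards the triazole.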